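Swapping the ester tail for a fluorophenyl ether

The compounds below may be only part of what the source reports. "The series", "measured", "known", "first", "only" and "open" are said of these compounds alone.

Three compounds share one core and differ only in the group carried at the far end. Compound 1 `CC(C)[C@H](NC(=O)COc1cccc2ccccc12)C(=O)N[C@@H](CC(=O)O)C(=O)COC(=O)c1c(Cl)cccc1Cl` ends in a (2,6-dichlorophenyl)carbonyl group; compound 2 `CC(C)[C@H](NC(=O)COc1cccc2ccccc12)C(=O)N[C@@H](CC(=O)O)C(=O)COc1ccc(Oc2ccccc2)cc1` and compound 3 `CC(C)[C@H](NC(=O)COc1cccc2ccccc12)C(=O)N[C@@H](CC(=O)O)C(=O)COc1ccc(Oc2ccc(C(F)(F)F)cc2)cc1` end in aryl ethers. In a functional assay on Jurkat cells (Homo sapiens) (on this read-out lower numbers stand for stronger inhibition and higher numbers for weaker inhibition), compound 1 gives 10600 nM, compound 2 gives 12700 nM and compound 3 gives 9300 nM. All three sit close together: the step of a 1.4-fold lower number from compound 2 to compound 3 (0.14 log units; within the scatter) lies within the scatter, and compound 1 stands second highest of the three, its gaps to compound 3 and compound 2 also within the scatter.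

Compound 4 `CC(C)[C@H](NC(=O)COc1cccc2ccccc12)C(=O)N[C@@H](CC(=O)O)C(=O)COc1ccc(F)cc1` is the unmeasured member. It differs from compound 1 by 4-fluorophenyl in place of (2,6-dichlorophenyl)carbonyl on an oxygen on a saturated carbon. Among the compounds with values here, no measured step covers this exact change, but compound 2 and compound 3 show that aryl ethers at this position land in the same range as the ester of compound 1. Compound 4 is therefore expected to show a step of about a 1.1-fold higher number from compound 1 to compound 4 (0.04 log units; within the scatter), nothing beyond the scatter. Compound 4 is estimated at 11500 nM in this assay, within 5000 nM to 26000 nM.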

Compound 4, half-maximal inhibitory concentration: > 100000 nM
Compound 4: no number, only a limit (the forecaster's own chance of this, stated with the estimate: 5%); at least 8.6-fold (0.93 log units) between middle value and limit.
By their numbers in this assay, from the lowest: compounds 3, 1 and 2 (each within the scatter of the next). At a limit, above all of these: compound 4.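

For compound 4, this assay gives only a limit of the assay and not a number: the limit of > 100000 nM in this assay, at which 1 of the 4 values shown sits. The earlier compounds shown here suggested that this position tolerates change, but replacing the ester tail with a small aryl ether gives an at least 9.4-fold higher number from compound 1 to compound 4 (0.97 log units; beyond the scatter). An aryl ether alone is therefore not enough: fluoro in place of phenoxy on an aromatic carbon gives an at least 7.8-fold higher number from compound 2 to compound 4 (0.89 log units; beyond the scatter), and fluoro in place of 4-(trifluoromethyl)phenoxy gives an at least 10-fold higher number from compound 3 to compound 4 (1.03 log units; beyond the scatter).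

Going by these compounds, it remains open whether this loss comes from the fluoro itself or simply from the absence of a larger phenoxy group. Compounds carrying hydrogen, a methoxy group or an amine on that same aromatic carbon would help separate these two readings.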